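The source may report more compounds than this note shows. Statements on the series, on what has been measured and on what is new or still open speak of the compounds shown alone.

Compound 1 `CCCOC(=O)N1N=C(c2ccccc2)CC1c1cc(OC)c(OC)c(OC)c1`: > 10000 nM
Compound 2 `COC(=O)N1N=C(c2cccc(OC)c2)CC1c1cc(OC)c(OC)c(OC)c1`: 2590 nM

Both compounds were tested in a functional assay on A549 cells (Homo sapiens) for antiproliferative activity, read by MTT assay, with a stated time of 48 h; on this read-out lower numbers stand for stronger inhibition of growth and higher numbers for weaker inhibition of growth. The entry for compound 1, > 10000 nM, is a limit of the assay and not a number. Among the compounds with values here, compound 2, at 2590 nM, therefore holds the only true number so far, and there is no measured scale on which to rank it.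

Compound 3 `COc1cccc(C2=NN(C(=O)OCc3ccccc3)C(c3cc(OC)c(OC)c(OC)c3)C2)c1` differs from compound 2 in one place: phenyl in place of hydrogen on a saturated chain carbon bound to an oxygen next to a carbonyl group. Put another way, methoxycarbonyl becomes benzyloxycarbonyl.

Within the data shown here, no measured pair shows what this change does, so any forecast is loose. Some loss of growth inhibition is expected, with the estimated change being a 1.9-fold higher number from compound 2 to compound 3 (0.29 log units; within the scatter). For compound 3 the estimate is 5000 nM, with an expected range of 1200 nM to 20000 nM.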

Compound 3, concentration for 50% growth inhibition: > 10000 nM
Compound 3: a limit, no number (the forecaster's own chance of this, stated with the estimate: 35%); middle value at least 2.0-fold (0.30 log units) away from the limit.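

Putting phenyl on this saturated chain carbon bound to an oxygen next to a carbonyl group, so that methoxycarbonyl becomes benzyloxycarbonyl, gives an at least 3.8-fold higher number from compound 2 to compound 3 (0.58 log units; beyond the scatter) in this assay, the first measured sign that this position is sensitive to change. The entry for compound 3, > 10000 nM, is a limit of the assay and not a number. The step therefore gives only a lower bound on the loss of growth inhibition, and its full size cannot be read because the result sits at a ceiling: the limit of > 10000 nM in this assay, at which 2 of the 3 values shown sit.

A single change at this position cannot show whether the loss comes with any added group or with phenyl alone. An amine or a carboxylic acid on this chain in place of phenyl remains an open case, and so does a simple ethyl group in place of the methyl of compound 2.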